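Swapping the dichlorophenyl on compound 3 for a pyridine ring

The source may report more compounds than this note shows. Statements on the series, on what has been measured and on what is new or still open speak of the compounds shown alone.

Of the compounds shown here, three built on one shared core have been measured in a functional assay on cells for positive allosteric modulation of metabotropic glutamate receptor 5 (Rattus norvegicus), read by calcium flux (on this read-out lower numbers stand for an effect already at smaller amounts and higher numbers for an effect only at larger amounts of compound), and they differ only in the aromatic ring attached to the carbonyl carbon. Compound 1 `O=C(Nc1cc(-c2ccccc2)nn1-c1ccccc1)c1cccc(C(F)(F)F)c1` gives 228 nM, compound 2 `Cc1ccc(C(=O)Nc2cc(-c3ccccc3)nn2-c2ccccc2)cc1` gives 64 nM, and compound 3 `O=C(Nc1cc(-c2ccccc2)nn1-c1ccccc1)c1ccc(Cl)c(Cl)c1` gives 13 nM. Compound 3 therefore stands at the lowest number of the three: the nearest other value, that of compound 2, is a 4.9-fold lower number from compound 2 to compound 3 (0.69 log units; beyond the scatter) away, and the step of an 18-fold lower number from compound 1 to compound 3 (1.24 log units; beyond the scatter) is larger still. The move a 3.6-fold lower number from compound 1 to compound 2 (0.55 log units; beyond the scatter) shows that even exchanging one substituted phenyl ring for another shifts this read-out.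

Compound 4 `O=C(Nc1cc(-c2ccccc2)nn1-c1ccccc1)c1ccncc1` takes the same step once more: pyridin-4-yl in place of 3,4-dichlorophenyl on a carbonyl carbon. All three measured steps bear on this position, and each of them went beyond the scatter, so a change at this ring is not expected to leave this assay untouched. What the measured compounds do not show is any example of a ring containing a nitrogen in place of a ring of carbon only, so the direction rests on the observation that compound 3 holds the lowest number and that every other ring tried gave a higher one. For compound 4 a clearly higher number than compound 3 is therefore expected, a step of about a 31-fold higher number from compound 3 to compound 4 (1.49 log units; beyond the scatter). The estimate for compound 4 in this assay is 400 nM, with a likely range from 100 nM to 2000 nM.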

Compound 4, half-maximal effective concentration: 2500 nM
Estimate against measurement, compound 4: 6.3-fold (0.80 log units) below; the measured number lies above the stated range.
By their numbers in this assay, from the lowest: compound 3; then compound 2; then compound 1; then compound 4.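

In this assay the pyridin-4-yl ring on the carbonyl carbon lands far from every earlier ring, with a 190-fold higher number from compound 3 to compound 4 (2.28 log units; beyond the scatter) when it replaces 3,4-dichlorophenyl, a 39-fold higher number from compound 2 to compound 4 (1.59 log units; beyond the scatter) when it replaces 4-methylphenyl, and an 11-fold higher number from compound 1 to compound 4 (1.04 log units; beyond the scatter) when it replaces 3-(trifluoromethyl)phenyl. The three rings of carbon only spanned a narrower range, whose widest step is an 18-fold lower number from compound 1 to compound 3 (1.24 log units; beyond the scatter) and which compound 4 lies well outside, at the high end. This position therefore tolerates some exchange among substituted phenyl rings, but the one ring here that contains a nitrogen and carries one hydrogen-bond acceptor gives by far the highest number of the four.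

Compound 4 differs from the others both in having a nitrogen in the ring and in having no substituent on it, so a plain phenyl ring, or a pyridine ring bearing chlorine atoms, would be needed to tell these two changes apart. The compounds shown offer no independent measurement that explains the size of this jump.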